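A few compounds are considered here, and "the series" means these few. Any claim that something is new, unique, unknown or untested is made for them only; others in the source may bear on it.

Cell toxicity is often the first check on a new molecule, since a compound that harms cells at low concentrations is of little use. Here the measure is an ADME assay on MT4 cells (Homo sapiens) for cytotoxicity, read by MTT assay, with a stated time of 96 h; a lower number here means that less compound is tolerated, a higher number that more compound is tolerated. Among the compounds with values here, in this test compound 1 `Fc1ccc(F)c(/N=N/Nc2ccccc2)c1` gives 100000 nM, the only exact number available so far. The only other result comes from compound 2 `CN1CCN(/N=N/c2cc(F)ccc2F)CC1`. Compound 2 reads > 100000 nM, which is a limit of the assay and not a number.

The next molecule, compound 3 `Fc1ccc(F)c(/N=N/Nc2cccc(C(F)(F)F)c2)c1`, keeps the core of compound 1 and changes it in one place: trifluoromethyl in place of hydrogen on an aromatic carbon. In words, trifluoromethyl stands in place of hydrogen on an aromatic carbon, meta to a large group. Within the data shown here, no measured pair of compounds shows what such a change does in this assay, so this forecast has little to lean on. No step beyond the usual scatter is expected, with only a slight lean towards less compound being tolerated. The expected change is a 1.7-fold lower number from compound 1 to compound 3 (0.22 log units; within the scatter). For compound 3 the estimated half-maximal cytotoxic concentration is 60000 nM, with an expected range of 20000 nM to 100000 nM.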

Compound 3, half-maximal cytotoxic concentration: > 100000 nM
Compound 3 ended at the assay's limit; the forecaster's own chance of this, stated with the estimate: 40%; at least 1.6-fold (0.22 log units) between middle value and limit.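

Within the data shown here, this is the first measured step at this position, and it shows that the shared core can carry a much larger group here without the number falling. In this assay, exchanging the hydrogen at this place, meta to a large group, for trifluoromethyl gives a number no lower from compound 1 to compound 3 (the limit leaves the size open). The size of this step cannot be read, and the result separates the compounds only weakly because the values pile up at one point: the limit of > 100000 nM in this assay, at which 2 of the 3 values shown sit.

The compounds shown therefore leave open how much higher the true number of compound 3 may lie, and whether trifluoromethyl has any real effect on how well the cells tolerate the compound. They also leave open whether a different group at this same place, such as an amine or a carboxylic acid, would bring the number down to a measurable value, which would show whether this position matters for cell toxicity at all.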